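Macrophage toxicity notes: phenoxy in place of 3-fluorophenyl

The compounds below may be only part of what the source reports. "The series", "measured", "known", "first", "only" and "open" are said of these compounds alone.

Compound 1 `O=C(Nc1cc(-c2ccccn2)n[nH]1)N1CCC(c2cccc(F)c2)CC1`: > 45000 nM
Compound 2 `O=C(Nc1cc(-c2ccccn2)n[nH]1)N1CCN(c2ccc(F)cc2)CC1`: > 57000 nM

Both entries come from an ADME assay on cells (Peritoneal macrophage cell, Mus musculus) for cytotoxicity, read by fluorescence and resazurin assay, with a stated time of 3 days; on this read-out higher numbers stand for lower toxicity in this test and lower numbers for higher toxicity in this test. Compound 1 stands only at a limit, > 45000 nM, and not at a number. Compound 2 likewise stands only at a limit, > 57000 nM. Within the data shown here, no order can be read from these two entries, and no measured step is available to set a size for a change.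

Compound 3 `O=C(Nc1cc(-c2ccccn2)n[nH]1)N1CCC(Oc2ccccc2)CC1` has phenoxy in place of 3-fluorophenyl on a saturated ring carbon of the core of compound 1 (phenoxy in place of 3-fluorophenyl on a saturated ring carbon). No step beyond the scatter is expected in this assay, and no direction is favoured. The expected step is a step that the limit leaves unreadable from compound 1 to compound 3. The estimate for compound 3 is 50000 nM, with an expected range from 20000 nM to 100000 nM. A report as a limit, and not as a number, is also expected to be likely.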

Compound 3, half-maximal cytotoxic concentration: > 40000 nM
Compound 3 gave a limit, no number (the forecaster's own chance of this, stated with the estimate: 70%); the middle value is on the limit's open side.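

Compound 1 and compound 3 are both reported only as limits, and no step can be read between them in this assay. The compounds shown leave open where any of their cytotoxic concentrations lies, and whether phenoxy in place of 3-fluorophenyl changes it at all.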